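This account rests on a few compounds, and the source may have more. Where it says the series, first, only, none or still open, it means among the compounds named here.

Compound 1 `CC(=O)N1N=C(c2ccc(OCc3cn(Cc4ccc([N+](=O)[O-])cc4)nn3)cc2)CC1c1ccccc1` was examined in a functional assay on A549 cells (Homo sapiens) for inhibition, read by sulforhodamine B assay, tested at 10 uM (a lower number here means less inhibition of growth, a higher number more inhibition of growth at the concentration tested), where compound 1 gives 15%. For the measured compounds named here, this is the lower of the two numbers known so far. Compound 2 `COc1cc(C2CC(c3ccc(OCc4cn(Cc5ccc([N+](=O)[O-])cc5)nn4)cc3)=NN2C(C)=O)ccc1Oc1cn(Cc2ccc([N+](=O)[O-])cc2)nn1` differs from compound 1 in several places; in this assay compound 2 gives 29%, a number beyond the scatter above it. Compound 3 `COc1ccc(C2CC(c3ccc(OCc4cn(Cc5ccc([N+](=O)[O-])cc5)nn4)cc3)=NN2C(C)=O)cc1` is not yet measured. Compared with compound 1, the change in compound 3 is methoxy in place of hydrogen on an aromatic carbon. Going by the values given here, with no single-point step between measured compounds to lean on, the step expected in this assay is a number 5 percentage points higher from compound 1 to compound 3 (within the scatter), small and upward, possibly within the scatter. Compound 3 is estimated at 20%, between 8% and 34%.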

Compound 3, percent growth inhibition at one concentration: 26%
For compound 3 the middle estimate is 6 percentage points below the measured one; low and high end bracket the measured number.
By their numbers in this assay, from the lowest: compound 1; then compounds 3 and 2 (each within the scatter of the next).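

In this assay, for the compounds shown here, methoxy in place of hydrogen on an aromatic carbon, para to a large group, gives a number 11 percentage points higher from compound 1 to compound 3 (beyond the scatter), the first step that can be read at a single place. It shows that this ring position responds to substitution, at least with this one group. Nothing at hand accounts for the step. The compounds shown leave open whether an amine or a carboxylic acid at the same place would move the number in the same direction, and whether a longer chain such as ethoxy would extend the step.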